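Sulfonamide to amide on the aryl ether arm of the core

This account rests on a few compounds, and the source may have more. Where it says the series, first, only, none or still open, it means among the compounds named here.

Compound 1 `CCN1C(=O)c2cc(C)nc(Oc3cccc(NS(=O)(=O)c4ccc(Cl)cc4)c3)c2C1=O`: 11 nM
Compound 2 `Cc1cc2c(c(Oc3cccc(NS(=O)(=O)c4ccc(Cl)cc4)c3)n1)C(=O)N(C(C)C)C2=O`: 13 nM

Two compounds were measured in a functional assay on HEK293 cells for agonist activity at Glucose-dependent insulinotropic receptor (Homo sapiens), read by cAMP accumulation, with a stated time of 30 min; on this read-out lower numbers stand for an effect already at smaller amounts and higher numbers for an effect only at larger amounts of compound. Compound 1 gives 11 nM, and compound 2 gives 13 nM. Going by the values given here, the single step between them, a 1.2-fold higher number from compound 1 to compound 2 (0.07 log units; within the scatter), concerns the substituent on the imide nitrogen of the shared core. Compound 2 stands with the highest of the two numbers, yet its gap to compound 1 lies within the scatter, so the two cannot be ordered.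

Compound 3 `Cc1cc2c(c(Oc3cccc(NC(=O)c4ccc(Cl)cc4)c3)n1)C(=O)N(C(C)C)C2=O` differs from compound 2 in another place altogether: (4-chlorophenyl)carbonyl in place of (4-chlorophenyl)sulfonyl on a nitrogen on an aromatic ring. Among the compounds with values here, no measured step touches this part of the molecule, and the step from compound 1 to compound 2 says nothing about it. The expectation for compound 3 therefore rests on no measured change, and a step of a 2.7-fold higher number from compound 2 to compound 3 (0.43 log units; beyond the scatter) in this assay is estimated with wide uncertainty. Compound 3 is expected to give about 35 nM, within a range from 7 nM to 200 nM.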

Compound 3, half-maximal effective concentration: > 30000 nM
Compound 3 was reported as a limit; the forecaster's own chance of this, stated with the estimate: 15%; middle value at least 850-fold (2.93 log units) from the limit.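

In this assay, going by these compounds alone, the exchange of (4-chlorophenyl)sulfonyl for (4-chlorophenyl)carbonyl on a nitrogen on an aromatic ring gives an at least 2300-fold higher number from compound 2 to compound 3 (3.36 log units; beyond the scatter), so this is the first place where a single change has a large effect on the read-out. The figure for compound 3 is a limit of the assay and not a number: the limit of > 30000 nM in this assay, at which 1 of the 3 values shown sits. Within the data shown here, the one change seen earlier, on the imide nitrogen, gave only a 1.2-fold higher number from compound 1 to compound 2 (0.07 log units; within the scatter), so the two places in the molecule respond very differently to the changes made at them.

Three compounds cannot show whether any group other than (4-chlorophenyl)sulfonyl is accepted on this nitrogen. On these data alone, it remains open how a methylsulfonyl group there, or a methyl group added to the same nitrogen, would read.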